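Exchanging the amide aryl group of the best-measured compound

This account rests on a few compounds, and the source may have more. Where it says the series, first, only, none or still open, it means among the compounds named here.

So far, three compounds have been measured in a functional assay on SK-BR-3 cells (Homo sapiens) for antiproliferative activity, read by MTT assay, with a stated time of 72 h; on this read-out lower numbers stand for stronger inhibition and higher numbers for weaker inhibition. Compound 1 `CCN1CCN(c2cc(C)c3cc(NC(=O)c4ccccc4F)ccc3n2)CC1` gives 38100 nM, compound 2 `CCc1ccc(C(=O)Nc2ccc3nc(N4CCN(CC)CC4)cc(C)c3c2)cc1` gives 9850 nM, and compound 3 `Cc1cc(N2CCCCC2)nc2ccc(NC(=O)c3ccc(Cl)c(Cl)c3)cc12` gives 42500 nM. Compound 2 thus stands lowest of the three; compound 1 is its nearest neighbour and compound 3 its furthest. Within the data shown here, the only single-point step among them is a 3.9-fold lower number from compound 1 to compound 2 (0.59 log units; beyond the scatter). Compound 4 `CCN1CCN(c2cc(C)c3cc(NC(=O)c4ccccc4Cl)ccc3n2)CC1` is the next compound, and its change from compound 2 is 2-chlorophenyl in place of 4-ethylphenyl on a carbonyl carbon. Among the measured compounds shown here, this change largely reverses the one measured step, putting a halogen-bearing phenyl back in place of 4-ethylphenyl, so a rise in the number is expected rather than a fall. The step is accordingly expected to be a 2.8-fold higher number from compound 2 to compound 4 (0.45 log units; beyond the scatter). Compound 4 is therefore estimated at 28000 nM, within a range from 9000 nM to 85000 nM.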

Compound 4, half-maximal inhibitory concentration: > 50000 nM
Compound 4 gave a limit, no number; the forecaster's own chance of this, stated with the estimate: 5%; middle value at least 1.7-fold (0.25 log units) away from the limit.
By their numbers in this assay, from the lowest: compound 2; then compounds 1 and 3 (each within the scatter of the next). At a limit, above all of these: compound 4.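

In this assay compound 4 gave a limit and not a number: the limit of > 50000 nM in this assay, at which 1 of the 4 values shown sits. The exchange of 4-ethylphenyl for 2-chlorophenyl on the carbonyl carbon gives an at least 5.0-fold higher number from compound 2 to compound 4 (0.70 log units; beyond the scatter), so 4-ethylphenyl now stands apart from both halogen-bearing phenyl groups shown at this place. Chloro in place of fluoro on an aromatic carbon gives an at least 1.3-fold higher number from compound 1 to compound 4 (0.11 log units; that floor lies within the scatter), and since that floor lies within the scatter, the two halogens cannot be told apart here.

Going by these compounds, it remains open whether the lower number belongs to the ethyl group itself or to where it sits on the ring. Also open, on these data alone, is what 4-chlorophenyl, 4-methoxyphenyl or a longer chain such as 4-butylphenyl would give on the same core.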